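Removing One Chloro Group a Second Time

This account rests on a few compounds, and the source may have more. Where it says the series, first, only, none or still open, it means among the compounds named here.

Three compounds share a core built on a fused system of two rings that carries chloro groups. Compound 1 is `ClCc1ccccc1Cn1cnc2c(Cl)nc(Cl)nc21`, compound 2 is `ClCc1ccccc1Cn1cnc2c(Cl)ncnc21`, and compound 3 is `ClCc1ccc(Cn2cnc3nc(Cl)nc(Cl)c32)cc1`. In a functional assay on RXF 393 cells (Homo sapiens) for cytotoxicity, read by sulforhodamine B assay, with a stated time of 48 h (on this read-out lower numbers stand for stronger inhibition of growth and higher numbers for weaker inhibition of growth), compound 1 gives 490 nM, compound 2 gives 2340 nM, and compound 3 gives 3980 nM.

Compound 1 and compound 2 differ in a single place: hydrogen in place of chloro on an aromatic carbon. This change gave a 4.8-fold higher number from compound 1 to compound 2 (0.68 log units; beyond the scatter), a step that lies beyond the usual scatter. Compound 3 has the same atoms as compound 1 joined differently; the difference between the two cores is not broken down here. Compound 3 shows the highest of the three numbers, but its gap to compound 2 lies within the scatter, so these two cannot be ranked against each other, while its gap to compound 1 lies beyond the scatter.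

Compound 4 is `ClCc1ccc(Cn2cnc3ncnc(Cl)c32)cc1` and has not yet been measured. It relates to compound 3 exactly as compound 2 relates to compound 1: hydrogen in place of chloro on an aromatic carbon. Among the compounds with values here, the expected outcome rests on the one earlier example, since the same change brought a 4.8-fold higher number from compound 1 to compound 2 (0.68 log units; beyond the scatter). On that basis the step is expected to be a 3.8-fold higher number from compound 3 to compound 4 (0.58 log units; beyond the scatter). Compound 4 is therefore estimated at 15000 nM, with a likely range from 5000 nM to 50000 nM.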

Compound 4, concentration for total growth inhibition: 4160 nM
Estimate against measurement, compound 4: 3.6-fold (0.56 log units) above, outside the stated range (below it).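

In this assay, putting hydrogen in place of the chloro group on the aromatic carbon between two ring nitrogen atoms gives a 1.0-fold higher number from compound 3 to compound 4 (0.02 log units; within the scatter), so compound 3 and compound 4 cannot be told apart on this read-out. The same single change therefore does not carry the same size of step from one core to the other, and a step seen on the core of compound 1 cannot simply be transferred to the core of compound 3: the same change on two cores in this assay, a 4.8-fold higher number (0.68 log units; beyond the scatter) from compound 1 to compound 2 and a 1.0-fold higher number (0.02 log units; within the scatter) from compound 3 to compound 4, 4.6-fold (0.66 log units) apart, beyond the scatter of two such steps. Within the data shown here, this does not show why the two cores answer differently, and with only two matched pairs it gives no rule for the series or for any further core, nor does it say which of the two steps would be the more typical one.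

The compounds shown leave open what an amine or a methoxy group would do on that same aromatic carbon, on either core, where so far only chloro and hydrogen can be compared. They also leave open whether the contrast between the two pairs would hold in cells other than the single line tested here, or with the remaining chloro group on the ring replaced by an amine.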